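Working notes: lengthening the acid chain of compound 2

The compounds below may be only part of what the source reports. "The series", "measured", "known", "first", "only" and "open" are said of these compounds alone.

For the measured compounds named here, of the two compounds measured so far, compound 2 `Cc1c(CC(=O)O)c2ccccc2n1Cc1ccc(O)c(C(C)C)c1` stands lowest: in an assay on CV-1 cells for agonist activity at thyroid hormone receptor beta (Homo sapiens), read by reporter gene assay, with a stated time of 10 h (a higher number here means that more compound is needed for the effect, a lower number that less compound is needed), compound 2 gives 150 nM. Compound 1 `Cc1cc2c(NC(=O)C(=O)O)cccc2n1Cc1ccc(O)c(C(C)C)c1` gives 590 nM in this assay, a higher number, beyond the scatter. Compound 3 `Cc1c(CCC(=O)O)c2ccccc2n1Cc1ccc(O)c(C(C)C)c1` is not yet measured; it differs from compound 2 by carboxymethyl in place of carboxy on a saturated chain carbon bound to an aromatic carbon. Going by the values given here, no step between measured compounds covers this change, so the expectation rests on compound 2 alone: a small shift in this assay is expected, more likely toward a higher number than a lower one, and only a little beyond the scatter at most. For compound 3 the value in this assay is estimated at 300 nM, range 80 nM to 1200 nM. The step of a 2.0-fold higher number from compound 2 to compound 3 (0.30 log units; within the scatter) is expected to be modest.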

Compound 3, half-maximal effective concentration: 37 nM
The estimate for compound 3 lay 8.1-fold (0.91 log units) above the measured number; measured number outside the range, below it.
By their numbers in this assay, from the lowest: compound 3; then compound 2; then compound 1.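

In this assay, carboxymethyl in place of carboxy on a saturated chain carbon bound to an aromatic carbon gives a 4.1-fold lower number from compound 2 to compound 3 (0.61 log units; beyond the scatter). For the compounds shown here, the number at this position therefore responds to a single added chain carbon, which compound 1 and compound 2 could not show, as no step linked them. Nothing on hand gives a reason for this step.

As far as these compounds go, whether a longer chain than 2-carboxyethyl lowers the number further or reverses the step remains open. So does whether an amide at the chain end could replace the carboxylic acid.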